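Aryl for Ethyl on the Ring Nitrogen: Expected Inhibition

The source may hold more compounds than are shown below. What is called first, only, known or untested is meant among the compounds shown, and "the series" means these compounds.

Measured so far:
compound 1, `CCN1C(=O)CSC1c1cccc(C(=O)NCCCCc2ccccc2)c1`, 0%
compound 2, `COc1ccccc1N1C(=O)CSC1C(=O)NCCCCc1ccccc1`, 0%

In a functional assay on HOS-TE85 cells (Homo sapiens) for inhibition, read by CCK-8 assay, with a stated time of 72 h, tested at 1 uM (on this read-out higher numbers stand for more inhibition at the one concentration tested (going by the name of the read-out) and lower numbers for less inhibition), compound 1 gives 0%. Compound 2 sits level with it: in this assay compound 2 gives 0%, and the two values lie within the usual scatter of each other, so neither number can be called the higher. Going by the values given here, no step between measured compounds that differ in a single place has been recorded.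

Compound 3, `O=C(NCCCCc1ccccc1)c1cccc(C2SCC(=O)N2c2ccccc2F)c1`, has not yet been measured in this assay. It differs from compound 1 in one place: 2-fluorophenyl in place of ethyl on an amide-type nitrogen in a ring. Among the compounds with values here, with no measured step of any kind to rest on, and with both known compounds showing no inhibition at the concentration tested, the account expects the step of a number 3 percentage points higher from compound 1 to compound 3 (within the scatter) to lie within the scatter and in no particular direction. Compound 3 is therefore estimated at 3%, within a range from -10% to 20%.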

Compound 3, a percentage reported as inhibition, at one concentration (the size of the read-out at that concentration, not a potency): 95%
For compound 3 the middle estimate is 92 percentage points below the measured one; the whole stated range lies below it.
By their numbers in this assay, from the lowest: compounds 1 and 2 (each within the scatter of the next); then compound 3.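

In this assay, the amide-type nitrogen in the ring emerges as a position that can decide the read-out: 2-fluorophenyl in place of ethyl gives a number 95 percentage points higher from compound 1 to compound 3 (beyond the scatter) on an otherwise unchanged structure. Going by these compounds alone, compound 1 and compound 2 sat level and gave no hint that the series could register at the single concentration tested, so this is the first sign that a change at this position can carry such a large step. No measurement available here accounts for the size of the step.

On these data alone, it remains open whether the ring itself or its fluorine matters, which unsubstituted phenyl, 2-chlorophenyl or benzyl on the same nitrogen could help separate. As far as these compounds go, a single concentration also gives no potency for compound 3, and it is unknown whether a longer chain such as butyl would behave like ethyl.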